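Acid series on the shared core: halogenated benzamide step

The compounds below may be only part of what the source reports. "The series", "measured", "known", "first", "only" and "open" are said of these compounds alone.

Measured so far:
compound 1 `CCOC(=O)c1sc(-c2cccc(NC(=O)c3ccccc3)c2)nc1Nc1ccc(N2CCN(C)CC2)cc1` gives 42%
compound 2 `CN1CCN(c2ccc(Nc3nc(-c4cccc(NC(=O)c5ccccc5)c4)sc3C(=O)O)cc2)CC1` gives 11.9%

Among the compounds with values here, in a functional assay on Raji cells (Homo sapiens) for antiproliferative activity, read by CCK-8 assay, with a stated time of 72 h, tested at 40 uM (on this read-out lower numbers stand for less inhibition and higher numbers for more inhibition at the one concentration tested (going by the name of the read-out)), compound 2 stands lowest of the two numbers; its nearest neighbour is compound 1, and the one measured step, hydrogen in place of ethyl on an oxygen next to a carbonyl group, runs a number 30.1 percentage points lower from compound 1 to compound 2 (beyond the scatter). Compound 3 `CN1CCN(c2ccc(Nc3nc(-c4cccc(NC(=O)c5ccc(F)c(Cl)c5)c4)sc3C(=O)O)cc2)CC1` carries the change (3-chloro-4-fluorophenyl in place of phenyl on a carbonyl carbon). Within the data shown here, no measured step touches the benzamido part, so nothing here bears on this change, and no step beyond the scatter is expected in this assay. For compound 3 the estimate is 18%, with a range from 2% to 40%, a step of a number 6.1 percentage points higher from compound 2 to compound 3 (within the scatter).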

Compound 3, a percentage reported as inhibition, at one concentration (the size of the read-out at that concentration, not a potency): 87.9%
Beside the measured number, compound 3's estimate is 69.9 percentage points below it; measured number above the stated range.
By their numbers in this assay, from the lowest: compound 2; then compound 1; then compound 3.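

The step on the carbonyl carbon, 3-chloro-4-fluorophenyl in place of phenyl, runs a number 76 percentage points higher from compound 2 to compound 3 (beyond the scatter) in this assay, so the benzamido part also moves this read-out strongly. Compound 3 keeps the carboxylic acid, so the acid alone does not hold the read-out low. Nothing at hand explains the size of this step. Open, from the compounds shown here alone, is whether chlorine alone or fluorine alone on the phenyl, or a trifluoromethyl group there, gives a similar step. Also open, going by these compounds, is how the ethyl ester behaves with 3-chloro-4-fluorophenyl in place.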